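Chloro for hydrogen on the aryl ring: tolerance in macrophages

The source may report more compounds than this note shows. Statements on the series, on what has been measured and on what is new or still open speak of the compounds shown alone.

Measured so far:
compound 1 `CCCCCCn1cc(COc2ccc(-c3cc(-c4ccc(C(C)C)cc4)nc(N)n3)c(O)c2)nn1` — "not determined" (no result reported)
compound 2 `CCCCCCn1cc(COc2ccc(-c3cc(-c4ccccc4)nc(N)n3)c(O)c2)nn1` — "not determined" (no result reported)
compound 3 `CCCCCCn1cc(COc2ccc3c(c2)OC(c2ccc(Br)cc2)CC3=O)nn1` — 20300 nM

For the measured compounds named here, compound 3 is the only member of the set with a number in an ADME assay on cells (Macrophage) for cytotoxicity, read by resazurin assay, with a stated time of 48 h; a lower number here means that less compound is tolerated, a higher number that more compound is tolerated; it gives 20300 nM. For compound 1 the entry in this assay reads "not determined" (no result reported), and compound 2 likewise gives "not determined" (no result reported), so compound 2 has no single value to stand on. Going by the values given here, compound 2 and compound 1 share a core that differs from that of compound 3, so the one number available does not carry over directly.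

Compound 4 `CCCCCCn1cc(COc2ccc(-c3cc(-c4ccc(Cl)cc4)nc(N)n3)c(O)c2)nn1` is the next entry to be measured in this assay. It differs from compound 2 by chloro in place of hydrogen on an aromatic carbon.

Among the compounds with values here, since compound 2 has no number, no step can be put alongside this change. Within the data shown here, on the one value at hand, compound 3, a tolerance in the same broad region is expected for compound 4, with no step beyond the scatter foreseen in either direction. Compound 4 is estimated at 15000 nM, with a range of 5000 nM to 45000 nM.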

Compound 4, half-maximal cytotoxic concentration: 30300 nM
The estimate for compound 4 lay 2.0-fold (0.31 log units) below the measured number; the range from low to high includes it.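

For the compounds shown here, compound 2 has no single number in this assay, so no step to compound 4 can be read. The compounds shown leave open how the change from phenyl to 4-chlorophenyl bears on tolerance in this assay. No supporting data bear on this result.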